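This account rests on a few compounds, and the source may have more. Where it says the series, first, only, none or still open, it means among the compounds named here.

Measured so far in a functional assay on MCF7 cells (Homo sapiens) for antiproliferative activity, read by MTT assay, with a stated time of 48 h; on this read-out lower numbers stand for stronger inhibition and higher numbers for weaker inhibition:

Compound 1 `COC/C1=C/C[C@](C)(CCC=C(C)C)/C=C/[C@@H](OC(=O)C=C(C)C)[C@](C)(OC)/C=C/C1=O` gives 16500 nM
Compound 2 `CC(=O)O[C@]1(C)/C=C/C(=O)/C(CO)=C\C[C@](C)(CCC=C(C)C)/C=C/[C@H]1OC(=O)C=C(C)C` gives 2320 nM

Of the two, compound 2 holds the lower number, and the gap to compound 1 at 16500 nM lies beyond the usual scatter of repeated measurements. Compound 2 is therefore the stronger inhibitor of this pair. The next compound, compound 3 `CO[C@]1(C)/C=C/C(=O)/C(CO)=C\C[C@](C)(CCC=C(C)C)/C=C/[C@H]1OC(=O)C=C(C)C`, differs from compound 2 in one place: methyl in place of acetyl on an oxygen on a saturated carbon, or acetoxy to methoxy.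

Among the measured compounds shown here, no step between measured compounds that differ in one place is available, so nothing shows directly what this exchange does in this assay. For the measured compounds named here, compound 2 stands at 2320 nM and the only other measured compound, compound 1, stands at 16500 nM on the weaker side. A moderate step to a higher number, only a little beyond the scatter, is therefore expected. The estimated change is a 2.2-fold higher number from compound 2 to compound 3 (0.33 log units; beyond the scatter) in size. Compound 3 is estimated at 5000 nM, with an expected range of 1800 nM to 14000 nM for the measurement.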

Compound 3, half-maximal inhibitory concentration: 14300 nM
Beside the measured number, compound 3's estimate is 2.9-fold (0.46 log units) below it; the whole stated range lies below it.
By their numbers in this assay, from the lowest: compound 2; then compounds 3 and 1 (each within the scatter of the next).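

In this assay, among the compounds shown here, the step of a 6.2-fold higher number from compound 2 to compound 3 (0.79 log units; beyond the scatter) gives the first direct reading of methyl in place of acetyl on an oxygen on a saturated carbon, and it shows that in this pair the acetoxy group goes with the lower number, while the methoxy group at the same place goes with a clearly higher one. The second new step, a 1.2-fold lower number from compound 1 to compound 3 (0.06 log units; within the scatter), is a different exchange, hydrogen in place of methyl on the other oxygen on a saturated carbon; with methoxy held at the first place, this exchange leaves the two compounds indistinguishable in this assay, so only the acetoxy to methoxy change moves the number beyond the scatter among the single-place steps shown. Nothing measured alongside these numbers gives a reason for either outcome.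

The compounds shown leave open what a bare hydrogen or a propanoyl group on the first oxygen would give, so it remains unknown whether the lower number belongs to the acetyl group alone or to acyl groups more widely. For the compounds shown here, they also leave open whether the hydroxymethyl group of compound 2 contributes to its number, since no compound carries the acetoxy group together with a methoxymethyl group or an aminomethyl group at that place.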